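Aryl swap on the bicyclic lactam core, cytotoxicity

A few compounds are considered here, and "the series" means these few. Any claim that something is new, unique, unknown or untested is made for them only; others in the source may bear on it.

Measured compounds:
compound 1, `COc1ccc(C2=C(c3ccco3)C(=O)N3CCCC3C2)cc1`: 6000 nM
compound 2, `CSc1ccc(C2=C(c3ccsc3)C(=O)N3CCCC3C2)cc1`: 600 nM

Both were run in a functional assay on HCT-116 cells (Homo sapiens) for cytotoxicity; on this read-out lower numbers stand for stronger inhibition and higher numbers for weaker inhibition. Compound 2 holds the lowest of the two numbers in this assay; compound 1 sits at a higher value, and the gap between the two lies beyond the usual scatter. The two structures differ in two places at once, so nothing can be attributed to either change alone.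

Compound 3, `CSc1ccc(C2=C(c3ccco3)C(=O)N3CCCC3C2)cc1`, is not yet measured. It takes from compound 2 one change only: furan-2-yl in place of thiophen-3-yl on a double-bonded ring carbon. The methylthio-bearing aryl group of compound 2 is kept.

Within the data shown here, no single-change step between measured compounds exists, so the size of this change in this assay is open. Compound 1, which carries the same furan-2-yl group together with a methoxy group, gives 6000 nM; that number cannot be split between its two differences from compound 2. The step from compound 2 to compound 3 is expected to be a modest loss, a 2.5-fold higher number from compound 2 to compound 3 (0.40 log units; beyond the scatter), with a wide range. Compound 3 is therefore estimated at 1500 nM, between 500 nM and 5000 nM.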

Compound 3, half-maximal inhibitory concentration: 3000 nM
The estimate for compound 3 lay 2.0-fold (0.30 log units) below the measured number, within the range that was stated.
By their numbers in this assay, from the lowest: compound 2; then compounds 3 and 1 (each within the scatter of the next).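

Furan-2-yl in place of thiophen-3-yl on the double-bonded ring carbon gives a 5.0-fold higher number from compound 2 to compound 3 (0.70 log units; beyond the scatter) in this assay, so this position responds to the exchange of one five-membered aromatic ring for another, even though the two groups match in heavy atoms and hydrogen-bond counts. Methylsulfanyl in place of methoxy on the aromatic carbon gives a 2.0-fold lower number from compound 1 to compound 3 (0.30 log units; within the scatter) with furan-2-yl held constant, so no separation between these two groups can be claimed in that setting. Of the two differences between compound 1 and compound 2, which could not be separated before, only the ring exchange now shows a step beyond the scatter.

No measurement on hand accounts for the size of either step.

The exchange changes the hetero atom and the point of attachment together, so thiophen-2-yl or furan-3-yl at the same carbon would be needed to tell these two apart. Among these compounds, whether methoxy and methylsulfanyl also stay within the scatter of each other alongside thiophen-3-yl remains open, as the only pair compared carries furan-2-yl.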